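A Second Methoxy Group on the Ester Aromatic Ring

The source may report more compounds than this note shows. Statements on the series, on what has been measured and on what is new or still open speak of the compounds shown alone.

Compound 1 `COC(=O)/C(=C\c1ccc(OC(=O)c2ccc(OC)cc2)cc1)Sc1ccnc2cc(Cl)ccc12` was tested in a functional assay on HL-60 cells (Homo sapiens) for cytotoxicity, read by MTT assay, with a stated time of 24 h (a lower number here means a stronger inhibitor, a higher number a weaker inhibitor), where compound 1 gives 9090 nM. For the measured compounds named here, of the two compounds measured so far, compound 1 has the lowest number; compound 2 `COC(=O)/C(=C\c1ccc(OC(=O)c2cc(OC)cc(OC)c2)cc1)Sc1ccnc2cc(Cl)ccc12` gives 19000 nM in this assay. Going by the values given here, the one step seen between them, a 2.1-fold higher number from compound 1 to compound 2 (0.32 log units; beyond the scatter), came from 3,5-dimethoxyphenyl in place of 4-methoxyphenyl on a carbonyl carbon.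

Compound 3 `COC(=O)/C(=C\c1ccc(OC(=O)c2c(OC)cccc2OC)cc1)Sc1ccnc2cc(Cl)ccc12` has not yet been measured. It differs from compound 1 by 2,6-dimethoxyphenyl in place of 4-methoxyphenyl on a carbonyl carbon. Among the compounds with values here, this is not the same change as the step from compound 1 to compound 2, but both replace 4-methoxyphenyl with a dimethoxyphenyl on a carbonyl carbon, so that step is the only available guide. Because a 2.1-fold higher number from compound 1 to compound 2 (0.32 log units; beyond the scatter) went toward a higher number, a modest move in the same direction is expected here as well, though a single step is a thin basis and the range is kept wide. Compound 3 is therefore estimated at 15000 nM, with a likely range of 7000 nM to 35000 nM. This estimate means a 1.7-fold higher number from compound 1 to compound 3 (0.22 log units; within the scatter) is expected.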

Compound 3, half-maximal inhibitory concentration: 37200 nM
Estimate against measurement, compound 3: 2.5-fold (0.39 log units) below, and the stated range ends below it.
By their numbers in this assay, from the lowest: compound 1; then compounds 2 and 3 (each within the scatter of the next).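

In this assay, the 2,6-dimethoxyphenyl group on the carbonyl carbon gives a 4.1-fold higher number from compound 1 to compound 3 (0.61 log units; beyond the scatter), so a second dimethoxyphenyl pattern also moves away from the number of the 4-methoxyphenyl compound, and here both dimethoxyphenyl compounds have higher numbers than compound 1. The comparison between the two dimethoxyphenyl patterns gives a 2.0-fold higher number from compound 2 to compound 3 (0.29 log units; within the scatter), so where the two methoxy groups sit on the ring makes no clear difference between these two compounds in this test. No measurement offered here explains why a dimethoxyphenyl group raises the number.

The compounds shown leave open how this ring would behave with no methoxy group at all, or with a hydroxyl group, an amine or a carboxylic acid in place of methoxy. They also leave open whether the same trend would hold if the ester linking this ring to the rest of the molecule were replaced by an amide, since every compound here carries that same ester.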